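Swapping the amine substituent on a shared core

The source may hold more compounds than are shown below. What is called first, only, known or untested is meant among the compounds shown, and "the series" means these compounds.

Compound 1, `O=C(CCc1ccc(C(F)(F)F)cc1)Nc1ccc2nc(N3CCC(NS(=O)(=O)O)C3)ccc2c1`: 50 nM in a functional assay on HEK293 cells for activation of melanin-concentrating hormone receptor 1 (Rattus norvegicus), read by inositol phosphate accumulation; on this read-out higher numbers stand for an effect only at larger amounts of compound and lower numbers for an effect already at smaller amounts
Compound 2, `CC(=O)NC1CCN(c2ccc3cc(NC(=O)CCc4ccc(C(F)(F)F)cc4)ccc3n2)C1`: 440 nM in this assay
Compound 3, `O=C(CCc1ccc(C(F)(F)F)cc1)Nc1ccc2nc(N3CC4CC3CO4)ccc2c1`: not yet measured

Within the data shown here, compound 2 carries the higher of the two numbers measured so far in this assay; its nearest neighbour is compound 1, and the only measured step, an 8.8-fold higher number from compound 1 to compound 2 (0.94 log units; beyond the scatter), separates them. Among the measured compounds shown here, that step is the sole guide available, and it touches the same position on the shared core that changes next. In compound 3 the change is a group of 7 heavy atoms (5 carbon, 1 nitrogen, 1 oxygen; 2 five-membered non-aromatic rings with 1 hetero atom each) in place of a group of 9 heavy atoms (6 carbon, 2 nitrogen, 1 oxygen; one five-membered non-aromatic ring with 1 hetero atom), on an aromatic carbon. This removes the acetamide altogether rather than exchanging it for another group, so the step from compound 1 to compound 2 does not describe it directly; it shows only that this substituent matters to the read-out, and that the amide version sits at the weaker end of what has been seen. Without a closer comparison, compound 3 is expected to land near compound 2 or somewhat weaker, with wide uncertainty: an estimated 800 nM in this assay, within a range from 150 nM to 4000 nM. This estimate corresponds to an expected step of a 1.8-fold higher number from compound 2 to compound 3 (0.26 log units; within the scatter).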

Compound 3, half-maximal effective concentration: 70 nM
Compound 3: middle estimate off by 11-fold (1.06 log units), on the high side; measured number outside the range, below it.
By their numbers in this assay, from the lowest: compounds 1 and 3 (each within the scatter of the next); then compound 2.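

In this assay, the earlier step showed only what happens when sulfo and acetyl are exchanged on the same amine nitrogen, whereas this result replaces the whole 3-acetamidopyrrolidin-1-yl group on the aromatic carbon. That larger change gives a 6.3-fold lower number from compound 2 to compound 3 (0.80 log units; beyond the scatter) and thus shows that the number at this position can shift beyond the scatter even when the entering group has 0 hydrogen-bond donors and no net charge. The comparison with the sulfo compound gives a 1.4-fold higher number from compound 1 to compound 3 (0.15 log units; within the scatter) within the scatter, so among these three compounds a value in this range does not depend on a sulfo group, although no measurement here explains why these groups give such similar or different numbers.

The compounds shown leave open which part of the entering group goes with the lower number, the second five-membered ring or its oxygen atom, since the two change together. A plain pyrrolidin-1-yl group and a morpholine on the same aromatic carbon would help separate these two parts, while a 3-aminopyrrolidin-1-yl group would show how a free amine compares with the sulfo and acetyl versions.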